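A thiazole amide traded for a chlorophenyl amide

The compounds below may be only part of what the source reports. "The series", "measured", "known", "first", "only" and "open" are said of these compounds alone.

Three amides on a shared core have been measured in a functional assay on HeLa cells (Homo sapiens) for antiproliferative activity, read by MTT assay, with a stated time of 72 h; on this read-out higher numbers stand for weaker inhibition and lower numbers for stronger inhibition. Compound 1 `O=C(Nc1ccc(Cl)c(-c2nnc3c(Cl)cccn23)c1)c1ccc(C(F)(F)F)cc1Cl` reaches the limit of the assay, > 100000 nM, which is the limit of > 100000 nM in this assay, at which 1 of the 3 values shown sits. Compound 3 `O=C(Nc1ccc(Cl)c(-c2nnc3c(Cl)cccn23)c1)c1ccc(C(F)(F)F)cc1F` gives 61900 nM in this assay. Among the measured compounds shown here, the step of an at least 1.6-fold lower number from compound 1 to compound 3 (0.20 log units; that floor lies within the scatter) is the only single change measured within the set. Compound 2 `Cc1nc(C(=O)Nc2ccc(Cl)c(-c3nnc4c(Cl)cccn34)c2)cs1` gives 79800 nM in this assay; it carries the higher of the two numbers shown, though compound 3 lies within the scatter of it, so the two are not told apart.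

Compound 4 `O=C(Nc1ccc(Cl)c(-c2nnc3c(Cl)cccn23)c1)c1cccc(Cl)c1` differs from compound 2 in one place: 3-chlorophenyl in place of 2-methyl-1,3-thiazol-4-yl on a carbonyl carbon. For the measured compounds named here, none of the measured steps touches the group on the carbonyl carbon; the single measured step concerns fluoro in place of chloro on an aromatic carbon of a different amide, and its size sits at a floor inside the scatter. The data therefore give no ground for expecting a move in either direction beyond the scatter, while a number close to the limit remains possible. Compound 4 is accordingly estimated at 70000 nM, with a range from 25000 nM to 150000 nM, which means an expected step of a 1.1-fold lower number from compound 2 to compound 4 (0.06 log units; within the scatter).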

Compound 4, half-maximal inhibitory concentration: > 100000 nM
Compound 4: no number, only a limit; the forecaster's own chance of this, stated with the estimate: 30%; at least 1.4-fold (0.15 log units) between middle value and limit.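

Compound 4 gives the first reading in which the group on the carbonyl carbon changes on an otherwise unchanged amide, and in this assay compound 4 yields a limit and not a number, the second such reading in the set: the limit of > 100000 nM in this assay, at which 2 of the 4 values shown sit.

The change of 2-methyl-1,3-thiazol-4-yl to 3-chlorophenyl reads as an at least 1.2-fold higher number from compound 2 to compound 4 (0.09 log units; that floor lies within the scatter), so it is known only as a floor, and that floor does not tell the two amides apart. What this position has shown so far is therefore narrow: exchanging a five-membered aromatic ring with 2 hetero atoms for a six-membered aromatic ring of carbon only did not lower the number, and the true size of the step cannot be read.

Still open, going by these compounds, is whether a plain phenyl, without the chlorine, would behave like the 3-chlorophenyl group on this carbonyl carbon. Also open, on these data alone, is whether a group of another kind there, such as a saturated ring carrying an amine or a short chain ending in a carboxylic acid, would bring the number down.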